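Fluorinated chain series: outlook for compound 4

This account rests on a few compounds, and the source may have more. Where it says the series, first, only, none or still open, it means among the compounds named here.

Compound 1 `O=c1[nH]c(=O)n([C@H]2C[C@H](O)[C@@H](CO)O2)cc1-c1cn(CCC(F)(F)C(F)(F)C(F)(F)C(F)(F)F)nn1` gives 97.8 uM in a functional assay on PC-3 cells (Homo sapiens) for antiproliferative activity, read by sulforhodamine B assay; on this read-out higher numbers stand for weaker inhibition of growth and lower numbers for stronger inhibition of growth. Compound 2 `O=c1[nH]c(=O)n([C@H]2C[C@H](O)[C@@H](CO)O2)cc1-c1cn(CCC(F)(F)C(F)(F)C(F)(F)C(F)(F)C(F)(F)C(F)(F)C(F)(F)C(F)(F)C(F)(F)C(F)(F)F)nn1` gives 89.4 uM in this assay, and compound 3 `O=c1[nH]c(=O)n([C@H]2C[C@H](O)[C@@H](CO)O2)cc1-c1cn(CCC(F)(F)C(F)(F)C(F)(F)C(F)(F)C(F)(F)C(F)(F)F)nn1` gives 115 uM in this assay. Compound 3 carries the highest of the three numbers, yet its gaps to compound 1 and to compound 2 both lie within the scatter, so no order among the three can be read. Compound 4 `O=c1[nH]c(=O)n([C@H]2C[C@H](O)[C@@H](CO)O2)cc1-c1cn(CCC(F)(F)C(F)(F)C(F)(F)C(F)(F)C(F)(F)C(F)(F)C(F)(F)C(F)(F)F)nn1` differs from compound 3 by 1,1,2,2,2-pentafluoroethyl in place of fluoro on a saturated chain carbon bound to two fluorine atoms and a saturated chain carbon. Going by the values given here, the one measured step of the same kind, a 1.2-fold higher number from compound 1 to compound 3 (0.07 log units; within the scatter), stayed within the scatter, and the values of compound 1 and compound 2 also sit within the scatter of each other. The step expected in this assay is therefore a 1.2-fold lower number from compound 3 to compound 4 (0.06 log units; within the scatter), nothing beyond the scatter. Compound 4 is estimated at 100 uM in this assay, within 55 uM to 180 uM.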

Compound 4, concentration for growth inhibition (reported as GI): 16.7 uM
Beside the measured number, compound 4's estimate is 6.0-fold (0.78 log units) above it; the measured number lies below the stated range.
By their numbers in this assay, from the lowest: compound 4; then compounds 2, 1 and 3 (each within the scatter of the next).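

At this position on the chain, the change from fluoro to 1,1,2,2,2-pentafluoroethyl is not neutral in this assay, as a 6.9-fold lower number from compound 3 to compound 4 (0.84 log units; beyond the scatter) shows. With a 5.4-fold lower number from compound 2 to compound 4 (0.73 log units; beyond the scatter) also beyond the scatter, the number does not run in one direction with chain length across compound 3, compound 4 and compound 2. The same change therefore gives different steps depending on the chain it is made on: the same change on two cores in this assay, a 1.2-fold higher number (0.07 log units; within the scatter) from compound 1 to compound 3 and a 5.4-fold higher number (0.73 log units; beyond the scatter) from compound 4 to compound 2, 4.6-fold (0.66 log units) apart, beyond the scatter of two such steps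

Going by these compounds, whether the lower number of compound 4 depends on the fluorine atoms or on chain length alone stays open. A plain hydrocarbon chain, or a chain ending in a carboxylic acid or an amine, would test this.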